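A few compounds are considered here, and "the series" means these few. Any claim that something is new, unique, unknown or untested is made for them only; others in the source may bear on it.

Working notes on the series. Compound 1 `CC(C)N(Cc1cccc(OCCCCCC(=O)O)c1)C(=O)c1ccc(-c2cccc(OCc3ccccc3)c2)cc1`, compound 2 `CCOC(=O)CCCCCOc1cccc(CN(C(=O)c2ccc(-c3cccnc3)cc2)C(C)C)c1` and compound 3 `CCOC(=O)CCCCCOc1cccc(CN(C(=O)c2ccc(-c3cc4ccccc4n3S(=O)(=O)c3ccccc3)cc2)C(C)C)c1` share one core and differ only in the group attached to it. In an ADME assay on BJ cells (Homo sapiens) for cytotoxicity, read by CellTiter-Glo and resazurin assay, with a stated time of 72 h (a lower number here means that less compound is needed, a higher number that more compound is needed for the effect), compound 1 gives > 26000 nM, which is a limit of the assay and not a number. In this assay compound 2 gives > 26000 nM, again a limit rather than a measured number. In this assay compound 3 gives > 26000 nM, also a limit. Where compound 2 stands can therefore only be said as a limit: every value so far sits at the limit of > 26000 nM in this assay, at which 3 of the 3 values shown sit, and no step between measured compounds can be stated, since the three results show only that none of the compounds produced a measurable effect over the concentrations tested.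

Compound 4 `CCOC(=O)CCCCCOc1cccc(CN(C(=O)c2ccc(-c3ccc(Cl)c(Cl)c3)cc2)C(C)C)c1` is the next compound to go into this assay. Relative to compound 2 it carries 3,4-dichlorophenyl in place of pyridin-3-yl on an aromatic carbon. With nothing in the measured set moving off the limit, the step from compound 2 to compound 4 in this assay is expected to be none beyond the scatter, as a step that the limit leaves unreadable from compound 2 to compound 4 expresses. Compound 4 is accordingly estimated at 30000 nM, with an expected range from 12000 nM to 80000 nM, most likely reported again as a limit.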

Compound 4, half-maximal effective concentration: > 26000 nM
Compound 4: a limit, no number; the forecaster's own chance of this, stated with the estimate: 85%; the middle value lies beyond the limit too.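

In this assay compound 4 gives > 26000 nM, which is a limit and not a number. No step can be read from compound 2 to compound 4, and the whole set stays at one limit: the limit of > 26000 nM in this assay, at which 4 of the 4 values shown sit. The compounds shown leave open whether any group on the shared core gives a measurable value in this assay.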